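The source may report more compounds than this note shows. Statements on the series, on what has been measured and on what is new or still open speak of the compounds shown alone.

In a functional assay on HL-60 cells (Homo sapiens) for cytotoxicity, read by MTT assay, with a stated time of 48 h (on this read-out lower numbers stand for stronger inhibition and higher numbers for weaker inhibition), two compounds have been measured so far. Compound 1 `O=c1ccc2cc(OCc3cc(-c4cccc(Cl)c4)no3)ccc2o1` gives 50600 nM in this assay. Compound 2 `O=c1ccc2cc(OCc3cn(-c4cccc([N+](=O)[O-])c4)nn3)ccc2o1` gives 20500 nM in this assay, the lowest of the two numbers; compound 1 stands at the higher number, and the gap between them lies beyond the usual scatter. Compound 3 `COc1ccccc1-n1cc(COc2ccc3oc(=O)ccc3c2)nn1` has not yet been measured. It differs from compound 2 in a single place: 2-methoxyphenyl in place of 3-nitrophenyl on an aromatic nitrogen. Going by the values given here, no measured pair shows what this change does, so the expectation rests on the two known values alone. One expects a step of modest size in this assay, more likely toward weaker inhibition than stronger, though a result within the scatter would not surprise. The estimate for compound 3 in this assay is 30000 nM, with a range from 10000 nM to 90000 nM. That estimate means an expected step of a 1.5-fold higher number from compound 2 to compound 3 (0.17 log units; within the scatter).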

Compound 3, half-maximal inhibitory concentration: 55200 nM
Compound 3: the middle estimate sits 1.8-fold (0.26 log units) below what was measured; measured number inside the range.
By their numbers in this assay, from the lowest: compound 2; then compounds 1 and 3 (each within the scatter of the next).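

In this assay, 2-methoxyphenyl in place of 3-nitrophenyl on an aromatic nitrogen of the five-membered ring gives a 2.7-fold higher number from compound 2 to compound 3 (0.43 log units; beyond the scatter), so the number at this position responds to the group placed there. Going by these compounds alone, this is the first measured step at this place, and with the shared core unchanged it runs toward weaker inhibition, although the step is modest in size. Nothing in the data on hand explains the direction or the size of this step.

This change replaces the nitro group with a methoxy group and also moves the substituent on the phenyl ring, so the two compounds cannot separate these effects. As far as these compounds go, it remains open where an unsubstituted phenyl, a 3-methoxyphenyl, or a phenyl bearing an amine or a carboxylic acid would stand relative to compound 2 and compound 3.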